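Chloro removal on the fluorosulfonyl ring: two positions compared

The compounds below may be only part of what the source reports. "The series", "measured", "known", "first", "only" and "open" are said of these compounds alone.

Measured so far:
compound 1, `CC1(C)N=C(N)N=C(N)N1c1ccc(CCCCc2cc(Cl)ccc2S(=O)(=O)F)c(Cl)c1`, in an assay on isolated protein for inhibition of Dihydrofolate reductase (Mus musculus) (on this read-out higher numbers stand for higher potency (the scale is a negative logarithm) and lower numbers for lower potency), gives 7.06
compound 2, `CC1(C)N=C(N)N=C(N)N1c1ccc(OCc2cccc(Cl)c2S(=O)(=O)F)c(Cl)c1`, in this assay gives 7.42
compound 3, `CC1(C)N=C(N)N=C(N)N1c1ccc(CCCCc2ccccc2S(=O)(=O)F)c(Cl)c1`, in this assay gives 7.77

Compound 1 and compound 3 share one core and differ by hydrogen in place of chloro on an aromatic carbon; the step is a number 0.71 log units higher from compound 1 to compound 3 (beyond the scatter). The difference between the core of compound 1 and the core of compound 2 is not broken down here. Compound 2 stands between the other two, with compound 3 higher and compound 1 lower.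

Compound 4, `CC1(C)N=C(N)N=C(N)N1c1ccc(OCc2ccccc2S(=O)(=O)F)c(Cl)c1`, is not yet measured. It differs from compound 2 by hydrogen in place of chloro on an aromatic carbon. This is the same kind of change as from compound 1 to compound 3, not the same: there the site is meta to a large group and para to a fluorosulfonyl group, here it is ortho to a fluorosulfonyl group and meta to a large group. Among the measured compounds shown here, only one such step is known, and on another core and another position, so the expectation is loose.

The step from compound 2 to compound 4 is expected as a number 0.33 log units higher from compound 2 to compound 4 (beyond the scatter), set smaller than the measured step because a number 0.71 log units higher from compound 1 to compound 3 (beyond the scatter) was found at a site that is para to a fluorosulfonyl group and on another core, whereas the site in compound 4 is ortho to a fluorosulfonyl group. Compound 4 is thus estimated at 7.75 in this assay, between 7.15 and 8.35.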

Compound 4, logarithm of the reciprocal of the active concentration, log(1/C): 7.43
Compound 4: the middle estimate sits 0.32 log units above what was measured; measured number inside the range.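

The change does not carry over from one core to another at a constant size in this assay: the same change on two cores in this assay, a number 0.71 log units higher (beyond the scatter) from compound 1 to compound 3 and a number 0.01 log units higher (within the scatter) from compound 2 to compound 4, 0.70 log units apart, beyond the scatter of two such steps On the core of compound 2, the step is a number 0.01 log units higher from compound 2 to compound 4 (within the scatter), so chloro and hydrogen ortho to a fluorosulfonyl group cannot be told apart on this read-out. The two steps differ both in the place of the chloro on the ring and in the rest of the molecule, and the pair does not show which of these accounts for the gap, nor does it give a rule for any other core in the series.

Open, from the compounds shown here alone, is how the same change behaves at the site used in compound 1 when placed on the core of compound 2, and at the site used in compound 2 when placed on the core of compound 1, which would separate site from core. Also open, going by these compounds, is whether a fluoro, methyl or methoxy group at either site would follow chloro or hydrogen.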